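A Methyl Added Where the Chain Meets the Core

The source may report more compounds than this note shows. Statements on the series, on what has been measured and on what is new or still open speak of the compounds shown alone.

Of the compounds shown here, three sharing one core have been measured in an ADME assay on Vero cells (Chlorocebus sabaeus) for cytotoxicity; a higher number here means that more compound is needed for the effect, a lower number that less compound is needed. Compound 1 `COc1cc(Nc2nc(C)cc(N(C)C)n2)ccc1F` gives 31600 nM in this assay. Compound 2 `COc1ccccc1NC(=O)c1ccc(Nc2nc(C)cc(N(C)C)n2)cc1` gives 631 nM in this assay. Compound 3 `Cc1cc(N(C)C)nc(NCc2ccccc2)n1` carries a different chain on the shared core. For compound 3 this assay reports only a limit, > 50100 nM, which is the limit of > 50100 nM in this assay, at which 1 of the 3 values shown sits. Compound 3 thus sits at the far end of what the measurements can show, and its distance from compound 1 or compound 2 cannot be fixed.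

Compound 4 `Cc1cc(N(C)C)nc(N[C@H](C)c2ccccc2)n1` has not yet been measured. It differs from compound 3 in one place: methyl in place of hydrogen on a saturated chain carbon bound to an aromatic carbon and a nitrogen on an aromatic ring. Among the compounds with values here, no two measured compounds differ by such a step, so there is no direct precedent. A single methyl is a small addition, and the expectation is a step no larger than the usual scatter, with compound 4 staying near the limit. The expected step in this assay is a number no higher from compound 3 to compound 4 (the limit leaves the size open). For compound 4 the estimate in this assay is 50000 nM, expected to fall between 20000 nM and 120000 nM.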

Compound 4, half-maximal effective concentration: > 50100 nM
Compound 4: no number, only a limit (the forecaster's own chance of this, stated with the estimate: 70%); middle value at least 1.0-fold (0.00 log units) away from the limit.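

In this assay compound 4 gives > 50100 nM, which is a limit and not a number. Compound 3 also stands at a limit, so no step can be read between compound 3 and compound 4. As far as these compounds go, how much the added methyl changes the value, if at all, stays open.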